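The source may report more compounds than this note shows. Statements on the series, on what has been measured and on what is new or still open speak of the compounds shown alone.

In an ADME assay on BJ cells (Homo sapiens), read by MTT assay, with a stated time of 72 h (a lower number here means a stronger inhibitor, a higher number a weaker inhibitor), compound 2, whose structure is `C#Cc1cn([C@@H]2O[C@H](CO)[C@@H](O)[C@H]2O)c2ncnc(OC)c12`, gives 98400 nM. For the measured compounds named here, this is the only number obtained in this assay, since the other value recorded there is a limit of the assay rather than a number. Compound 1, with the structure `CNc1ncnc2c1c(I)cn2[C@@H]1O[C@H](CO)[C@@H](O)[C@H]1O`, reaches only a limit in this assay, > 100000 nM. Compound 2 thus stands as the sole measured figure, and it sits close to the limit of > 100000 nM in this assay, at which 1 of the 2 values shown sits, so the two compounds cannot be ordered against each other.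

Compound 3, whose structure is `COc1ncnc2c1c(I)cn2[C@@H]1O[C@H](CO)[C@@H](O)[C@H]1O`, has not yet been measured in this assay. It differs from compound 2 by iodo in place of ethynyl on an aromatic carbon. Going by the values given here, no measured step between two compounds that differ in one place is available, so no size or direction of change can be read from the data. Compound 2 already lies near the limit of this assay, and the expected step is therefore small, a 1.2-fold higher number from compound 2 to compound 3 (0.09 log units; within the scatter), not beyond the usual scatter. For compound 3 the estimate in this assay is 120000 nM, with a range from 40000 nM to 400000 nM, and a report of only a limit is considered likely.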

Compound 3, half-maximal inhibitory concentration: 91000 nM
The estimate for compound 3 lay 1.3-fold (0.12 log units) above the measured number; the measured number falls inside the stated range.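

In this assay, the aromatic carbon of the five-membered ring now has its first readable change: iodo in place of ethynyl gives a 1.1-fold lower number from compound 2 to compound 3 (0.03 log units; within the scatter), so this read-out does not tell the two groups apart at this place. Methoxy in place of methylamino on an aromatic carbon gives an at least 1.0-fold lower number from compound 1 to compound 3 (0.04 log units; that floor lies within the scatter), a step known only as a floor, since the value it starts from is a limit of the assay and not a number. Neither step therefore shows any group making a clear difference, and both stay in the region where the assay reaches its limit: the limit of > 100000 nM in this assay, at which 1 of the 3 values shown sits.

On these data alone, it remains open whether a different group on the five-membered ring, such as an amine or a longer chain, would move the number clearly away from that limit, since ethynyl and iodo alone cannot show how far this place can respond. As far as these compounds go, it also remains open how methylamino and methoxy truly compare on the shared core, and whether a primary amine on that aromatic carbon would give a number that can be read against them.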